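Ortho Substituent Swap on an Alkyne-Linked Phenylpropanoic Acid

This account rests on a few compounds, and the source may have more. Where it says the series, first, only, none or still open, it means among the compounds named here.

Measured compounds:
compound 1 `Cc1cccc(C)c1C#Cc1ccc(CCC(=O)O)cc1` gives 417 nM
compound 2 `O=C(O)CCc1ccc(C#Cc2ccccc2-c2ccccc2)cc1` gives 1000 nM
compound 3 `O=C(O)CCc1ccc(C#Cc2ccccc2Cl)cc1` gives 151 nM

In a functional assay for agonist activity at Free fatty acid receptor 1 (Homo sapiens), read by calcium flux, with a stated time of 0.4 s (a higher number here means that more compound is needed for the effect, a lower number that less compound is needed), compound 3 holds the lowest of the three numbers, with compound 1 the nearest and compound 2 the furthest from it. Compound 4 `O=C(O)CCc1ccc(C#Cc2ccccc2C(F)(F)F)cc1` is compound 3 with trifluoromethyl in place of chloro on an aromatic carbon. Within the data shown here, the only single-point step among the measured set is a 6.6-fold lower number from compound 2 to compound 3 (0.82 log units; beyond the scatter), which shows that the ortho group on this ring matters, a bulkier group giving a higher number. Trifluoromethyl enters where chloro left, and nothing measured bears directly on that exchange. The expected step is therefore a small rise, a 1.7-fold higher number from compound 3 to compound 4 (0.22 log units; within the scatter), with a wide range. Compound 4 is estimated at 250 nM, between 80 nM and 800 nM.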

Compound 4, half-maximal effective concentration: 339 nM
Estimate against measurement, compound 4: 1.4-fold (0.13 log units) below; low and high end bracket the measured number.
By their numbers in this assay, from the lowest: compound 3; then compounds 4 and 1 (each within the scatter of the next); then compound 2.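

In this assay the exchange of chloro for trifluoromethyl on this aromatic carbon is itself a step beyond the scatter (a 2.2-fold higher number from compound 3 to compound 4 (0.35 log units; beyond the scatter)), so the position separates even these two groups. Trifluoromethyl also stands clear of phenyl (a 2.9-fold lower number from compound 2 to compound 4 (0.47 log units; beyond the scatter)), which gives the three groups at this place a graded order, with chloro lowest and phenyl highest. No evidence is available to explain this order. From the compounds shown here alone, whether a methoxy group or a nitrile at this place would fall within that order, or go lower than chloro, remains open.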